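Replacing a Sulfur Ring with an Alcohol-Bearing Chain

The compounds below may be only part of what the source reports. "The series", "measured", "known", "first", "only" and "open" are said of these compounds alone.

The compounds here form two pairs built on closely related cores. Compound 1, `C(=C/c1[nH]cnc2ncnc1-2)\c1ccsc1`, carries a thiophen-3-yl group at the end of a double-bonded chain. Compound 2, `C(=C/c1ncnc2c1ncn2C1CCOCC1)\c1ccsc1`, carries the same group on a different core; the difference between the two cores is not broken down here. Compound 3, `C/C(=C\C=C\c1[nH]cnc2ncnc1-2)CO`, is compound 1 with one change: 2-(hydroxymethyl)prop-1-en-1-yl in place of thiophen-3-yl on a double-bonded chain carbon bound to a double-bonded chain carbon. Compound 4, `C/C(=C\C=C\c1ncnc2c1ncn2C1CCOCC1)CO`, has not yet been tested and is compound 2 with the same change: 2-(hydroxymethyl)prop-1-en-1-yl in place of thiophen-3-yl on a double-bonded chain carbon bound to a double-bonded chain carbon.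

In a functional assay on K562 cells (Homo sapiens) for inhibition, read by thymidine incorporation, with a stated time of 48 h, tested at 10 ug/mL (on this read-out higher numbers stand for more inhibition at the one concentration tested (going by the name of the read-out) and lower numbers for less inhibition), compound 1 gives 32%, and compound 2 gives 58%, the highest number among the three measured compounds. Compound 3 gives 6%. The step of a number 26 percentage points lower from compound 1 to compound 3 (beyond the scatter) shows that trading the thiophen-3-yl group for the 2-(hydroxymethyl)prop-1-en-1-yl group costs a clear amount of inhibition on the core of compound 1.

Going by the values given here, whether the same change costs as much on the core of compound 2 cannot be known from a single example, but that example is the only guide available, and the change is the same in both pairs. The expectation for compound 4 therefore rests on the step of a number 26 percentage points lower from compound 1 to compound 3 (beyond the scatter) being carried over to the core of compound 2. The step from compound 2 to compound 4 is thus expected to be a number 26 percentage points lower from compound 2 to compound 4 (beyond the scatter). Compound 4 is estimated to give about 32% in this assay, most likely between 14% and 50%.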

Compound 4, a percentage reported as inhibition, at one concentration (the size of the read-out at that concentration, not a potency): 27%
Compound 4: middle estimate off by 5 percentage points, on the high side; the measured number falls inside the stated range.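

Swapping thiophen-3-yl for 2-(hydroxymethyl)prop-1-en-1-yl on the second core gives a number 31 percentage points lower from compound 2 to compound 4 (beyond the scatter) in this assay. Set beside the earlier step, this shows that the loss of inhibition carried over from one core to the other, with no difference between the two steps that stands out from the normal variation in such measurements: the same change on two cores in this assay, a number 26 percentage points lower (beyond the scatter) from compound 1 to compound 3 and a number 31 percentage points lower (beyond the scatter) from compound 2 to compound 4, 5 percentage points apart, within the scatter of two such steps

Going by these compounds alone, this agreement rests on only two pairs of compounds, each tested at a single concentration in one kind of cell, so it does not show that the change would cost the same on a third core, and it does not explain why inhibition falls.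

The compounds shown also leave open which part of the swap matters, since the thiophene ring and its sulfur leave at the same moment as the open chain and its alcohol enter. What a chain ending in an amine or a carboxylic acid would give on either core remains an open question, as does the result of a longer chain or of a phenyl ring in the same place.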